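The source may report more compounds than this note shows. Statements on the series, on what has been measured and on what is new or still open speak of the compounds shown alone.

Compound 1 `C=CS(=O)(=O)N1CCN(c2ncnc3sc(-c4cccc5ccccc45)cc23)CC1` gives 23700 nM
Compound 2 `C=CS(=O)(=O)N1CCN(c2ncnc3sc(-c4cc(Br)cnc4F)cc23)CC1` gives 24100 nM

In a functional assay on MDA-MB-231 cells (Homo sapiens) for antiproliferative activity, read by MTT assay, with a stated time of 48 h (a lower number here means a stronger inhibitor, a higher number a weaker inhibitor), compound 2 gives 24100 nM, which lies within the scatter of the value for compound 1, so it holds no separate rank. Compound 3 `C=CS(=O)(=O)N1CCN(c2ncnc3sc(-c4c(C)noc4C)cc23)CC1` has 3,5-dimethyl-1,2-oxazol-4-yl in place of 5-bromo-2-fluoropyridin-3-yl on an aromatic carbon, next to the ring sulfur: 3,5-dimethyl-1,2-oxazol-4-yl in place of 5-bromo-2-fluoropyridin-3-yl on an aromatic carbon. Within the data shown here, one measured step bears on this change, at the same place: a 1.0-fold higher number from compound 1 to compound 2 (0.01 log units; within the scatter), where 5-bromo-2-fluoropyridin-3-yl replaced naphthalen-1-yl. That step stays within the scatter, so no step beyond the scatter is expected in this assay, and no direction is favoured. Among the measured compounds shown here, this rests on a single step, and no measured compound carries 3,5-dimethyl-1,2-oxazol-4-yl. The expected change is a 1.0-fold lower number from compound 2 to compound 3 (0.02 log units; within the scatter). Compound 3 is estimated at 23000 nM, with an expected range from 11000 nM to 48000 nM.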

Compound 3, half-maximal inhibitory concentration: 28200 nM
For compound 3 the middle estimate is 1.2-fold (0.09 log units) below the measured one; measured number inside the range.
By their numbers in this assay, from the lowest: compounds 1, 2 and 3 (each within the scatter of the next).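

In this assay, 3,5-dimethyl-1,2-oxazol-4-yl in place of 5-bromo-2-fluoropyridin-3-yl on the aromatic carbon next to the ring sulfur gives a 1.2-fold higher number from compound 2 to compound 3 (0.07 log units; within the scatter), and the same group in place of naphthalen-1-yl gives a 1.2-fold higher number from compound 1 to compound 3 (0.08 log units; within the scatter). A five-membered aromatic ring with 2 hetero atoms therefore joins a six-membered aromatic ring with 1 hetero atom and naphthalen-1-yl at this position, and the three compounds cannot be told apart in this read-out. Nothing available accounts for this lack of separation.

On these data alone, all three groups here are aromatic rings, so it remains open whether an amine, a carboxylic acid or a longer alkyl chain on this carbon would give a step beyond the scatter. The compounds shown also leave open how far changes elsewhere on the shared core would move the number.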